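The source may hold more compounds than are shown below. What is called first, only, known or untested is meant among the compounds shown, and "the series" means these compounds.

In an assay for inhibition of Indoleamine 2,3-dioxygenase 1 (Homo sapiens), read by spectrophotometry, with stated times of 1 h and 4 h (a higher number here means a weaker inhibitor, a lower number a stronger inhibitor), three closely related compounds have been measured. Compound 1 `COc1ccc(NNS(=O)(=O)c2ccc(NC(C)=O)cc2)cc1` gives 254 nM, compound 2 `CC(=O)Nc1ccc(S(=O)(=O)NNc2ccc(Br)cc2)cc1` gives 130 nM, and compound 3 `CC(=O)Nc1ccc(S(=O)(=O)NNc2ccc(Br)c(F)c2)cc1` gives 205 nM. Compound 2 has the lowest of the three numbers, yet its gaps to the other two are small: a 2.0-fold lower number from compound 1 to compound 2 (0.29 log units; within the scatter) and a 1.6-fold higher number from compound 2 to compound 3 (0.20 log units; within the scatter), both within the scatter, so no ranking among the three can be claimed.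

Compound 4 `O=C(O)CCc1ccc(S(=O)(=O)NNc2ccc(Br)cc2)cc1` has not yet been measured. It differs from compound 2 in one place: 2-carboxyethyl in place of acetamido on an aromatic carbon. Both measured steps concern the ring that carries the bromo group, not the part of the molecule altered here, and both stayed within the scatter. Within the data shown here, no measured step therefore speaks directly to the change from compound 2 to compound 4, and swapping an acetamido for a 2-carboxyethyl is untested. Since neither measured step moved the number beyond the scatter, the expectation for compound 4 is at most a modest rise, with a wide range reflecting the lack of a direct precedent. Compound 4 is thus estimated at 300 nM, with a likely range from 80 nM to 1500 nM. This estimate means an expected step of a 2.3-fold higher number from compound 2 to compound 4 (0.36 log units; beyond the scatter).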

Compound 4, half-maximal inhibitory concentration: 141 nM
For compound 4 the middle estimate is 2.1-fold (0.33 log units) above the measured one, within the range that was stated.
By their numbers in this assay, from the lowest: compounds 2, 4, 3 and 1 (each within the scatter of the next).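

In this assay, 2-carboxyethyl in place of acetamido gives a 1.1-fold higher number from compound 2 to compound 4 (0.04 log units; within the scatter), so compound 2 and compound 4 cannot be told apart. This is the only step shown at this position, on the aromatic carbon para to a large group, and it shows that two quite different groups can sit here with no difference beyond the scatter. The earlier steps shown here changed only the ring that carries the bromo group. No measurement shown here explains why the swap of an acetamido group, which contains nitrogen, for a carbon chain ending in a carboxylic acid leaves the number within the scatter.

Going by these compounds, a single swap cannot show how far this tolerance extends, so it remains open whether a carboxylic acid set directly on the ring, a longer chain ending in a carboxylic acid, a simple amine or a methyl ester would also stay within the scatter of compound 2. On these data alone, it is also open whether the 2-carboxyethyl group would behave the same way alongside a different group on the other ring, such as the methoxy of compound 1.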